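The compounds below may be only part of what the source reports. "The series", "measured", "known", "first", "only" and "open" are said of these compounds alone.

Working notes on the series. The shared core is that of compound 1 `O=C(/C=C\c1ccccc1[N+](=O)[O-])N1N=C(c2ccncc2)OC1c1c[nH]c2ccccc12`. In an ADME assay on PANC-1 cells (Homo sapiens) for cytotoxicity, read by MTT assay, with a stated time of 48 h (on this read-out higher numbers stand for weaker inhibition of growth and lower numbers for stronger inhibition of growth), compound 1 gives > 30 ug/mL, which is a limit of the assay and not a number. Compound 2 `Cc1ccc(/C=C\C(=O)N2N=C(c3ccncc3)OC2c2c[nH]c3ccccc23)cc1` carries 4-methylphenyl in place of 2-nitrophenyl on a double-bonded chain carbon bound to a double-bonded chain carbon. In this assay compound 2 gives > 30 ug/mL, again a limit of the assay and not a number. The step that the two limits leave unreadable from compound 1 to compound 2 is therefore hidden by the two limits, and neither its size nor its direction can be read. All that the measured compounds show is the limit of > 30 ug/mL in this assay, at which 2 of the 2 values shown sit.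

Compound 3 `O=C(/C=C\c1cccc(Br)c1)N1N=C(c2ccncc2)OC1c1c[nH]c2ccccc12` is not yet measured. It differs from compound 1 by 3-bromophenyl in place of 2-nitrophenyl on a double-bonded chain carbon bound to a double-bonded chain carbon. Within the data shown here, no measured step bears on this change: the one step known, a step that the two limits leave unreadable from compound 1 to compound 2, gives no readable size, so no expectation of size or direction in this assay can be drawn from it beyond the scatter.

In this assay compound 3 is expected to give about 40 ug/mL, with a range from 15 ug/mL to 120 ug/mL, and is likely to be reported only as a limit again. The estimated step that the limit leaves unreadable from compound 1 to compound 3 rests on the limit of compound 1 alone.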

Compound 3, concentration for 50% growth inhibition: > 30 ug/mL
Compound 3: a limit, no number; the forecaster's own chance of this, stated with the estimate: 60%; the middle value does not contradict the limit.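

In this assay compound 3 gives > 30 ug/mL, a limit of the assay and not a number. The steps to compound 3 from compound 1 and from compound 2 therefore cannot be read: the limit of > 30 ug/mL in this assay, at which 3 of the 3 values shown sit.

The compounds shown leave open whether 2-nitrophenyl, 4-methylphenyl and 3-bromophenyl differ at all in this assay.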